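The source may hold more compounds than are shown below. What is called first, only, known or untested is meant among the compounds shown, and "the series" means these compounds.

Values measured in a functional assay on LNCaP cells (Homo sapiens) for antiproliferative activity; on this read-out lower numbers stand for stronger inhibition and higher numbers for weaker inhibition:

- compound 1 `CNC(=O)C[C@@H]1C[C@@H](c2ccc(Cl)c(Cl)c2)[C@H](NC(=O)c2cc(-c3c(Cl)cnn3C)c(Cl)o2)CN1`: 40 nM
- compound 2 `Cn1ncc(Cl)c1-c1cc(C(=O)N[C@@H]2CN[C@H](CC(N)=O)C[C@H]2c2ccc(Cl)c(Cl)c2)oc1Cl`: 160 nM
- compound 3 `Cn1ncc(Cl)c1-c1cc(C(=O)N[C@@H]2CN[C@H](CC(=O)NCC(O)CO)C[C@H]2c2ccc(Cl)c(Cl)c2)oc1Cl`: 660 nM

Compound 3 has the highest number of the three, so it is the weakest inhibitor in the set. Compound 2 lies nearest to it and compound 1 furthest away. The next compound, compound 4 `Cn1ncc(Cl)c1-c1cc(C(=O)N[C@@H]2CN[C@H](CC(=O)NC3CCC3)C[C@H]2c2ccc(Cl)c(Cl)c2)oc1Cl`, carries cyclobutyl in place of 2,3-dihydroxypropyl on an amide-type nitrogen.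

For the measured compounds named here, three measured steps bear on this change. The closest is a 4.1-fold higher number from compound 2 to compound 3 (0.62 log units; beyond the scatter), which brings in the same 2,3-dihydroxypropyl on that nitrogen in place of hydrogen. The step of a 17-fold higher number from compound 1 to compound 3 (1.22 log units; beyond the scatter) is larger, and a 4.0-fold higher number from compound 1 to compound 2 (0.60 log units; beyond the scatter) shows that the number also moves when only a methyl on that nitrogen is lost. Going by the values given here, no measured compound has a ring on this nitrogen, so the size of the cyclobutyl effect remains uncertain. With 2,3-dihydroxypropyl gone, a modest to large fall in the number is expected, placing compound 4 nearer to compound 1 and compound 2 than to compound 3.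

The estimated change is a 7.3-fold lower number from compound 3 to compound 4 (0.87 log units; beyond the scatter). Compound 4 is expected at about 90 nM, within an estimated range of 30 nM to 270 nM.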

Compound 4, half-maximal inhibitory concentration: 80 nM
Compound 4: the middle estimate sits 1.1-fold (0.05 log units) above what was measured, within the range that was stated.
By their numbers in this assay, from the lowest: compounds 1, 4 and 2 (each within the scatter of the next, the first and the last beyond it); then compound 3.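

In this assay, setting cyclobutyl in place of 2,3-dihydroxypropyl on the amide-type nitrogen gives an 8.3-fold lower number from compound 3 to compound 4 (0.92 log units; beyond the scatter), so the high number of compound 3 does not follow simply from carrying something larger than methyl at this place. Compound 4 also sits within the scatter of both simpler amides, at a 2.0-fold lower number from compound 2 to compound 4 (0.30 log units; within the scatter) and at a 2.0-fold higher number from compound 1 to compound 4 (0.30 log units; within the scatter), even though compound 1 and compound 2 lie beyond the scatter of each other, so this ring is accepted on the nitrogen but cannot be ranked against hydrogen or methyl. Nothing available explains why compound 3 stands apart from the other three.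

The step to compound 4 removes both hydroxyl groups and brings in a ring at once, so the compounds shown cannot say which of the two changes matters. From the compounds shown here alone, what an open propyl chain, a chain with a single hydroxyl, a larger ring such as cyclohexyl, or a chain ending in an amine or a carboxylic acid would give on this nitrogen remains open.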